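Replacing a methylpiperazine by a methoxyethylamine on a shared core

A few compounds are considered here, and "the series" means these few. Any claim that something is new, unique, unknown or untested is made for them only; others in the source may bear on it.

Measured so far in a functional assay on BaF3 cells (Mus musculus) for inhibition, read by CCK-8 assay, with a stated time of 72 h; a lower number here means a stronger inhibitor of growth, a higher number a weaker inhibitor of growth:
compound 1, `Cc1ccc(NC(=O)Nc2ccc(Oc3cc(N4CCNC[C@H]4C)ncn3)cc2)cc1C(F)(F)F`, gives 9670 nM
compound 2, `Cc1ccc(NC(=O)Nc2ccc(Oc3cc(N4CCNC[C@@H]4C)ncn3)cc2)cc1C(F)(F)F`, gives 8120 nM
compound 3, `Cc1ccc(NC(=O)Nc2ccc(Oc3cc(N4CCN[C@H](C)C4)ncn3)cc2)cc1C(F)(F)F`, gives 8920 nM

All three compounds share one core and differ only in the group on the aromatic carbon of that core. The step of a 1.2-fold lower number from compound 1 to compound 2 (0.08 log units; within the scatter) rests on (the fact that compounds 1 and 2 differ only in the configuration as drawn), so the two drawings of the same methylpiperazine give the same picture. Moving the methyl from one ring position to the other gives a 1.1-fold lower number from compound 1 to compound 3 (0.04 log units; within the scatter) and a 1.1-fold higher number from compound 2 to compound 3 (0.04 log units; within the scatter), so compound 3 sits between compound 1 and compound 2 with all three numbers inside the usual scatter of one another.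

Compound 4, `COCCNc1cc(Oc2ccc(NC(=O)Nc3ccc(C)c(C(F)(F)F)c3)cc2)ncn1`, carries the change ((2-methoxyethyl)amino in place of 3-methylpiperazin-1-yl on an aromatic carbon). None of the three measured steps touches the group that leaves here; each of them only rearranges a methyl or a drawn configuration on the ring that is now removed, and each stays within the scatter. Going by the values given here, they therefore offer no direction for the step in this assay from a ring to an open chain, and the expectation has to stay wide. Compound 4 is expected to give about 8000 nM, with a range from 2000 nM to 30000 nM. The step of a 1.1-fold lower number from compound 3 to compound 4 (0.05 log units; within the scatter) is thus expected to be small against the scatter, with the range open to either side.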

Compound 4, concentration for 50% growth inhibition: 7950 nM
Compound 4: middle estimate off by 1.0-fold (0.00 log units), on the high side; low and high end bracket the measured number.
By their numbers in this assay, from the lowest: compounds 4, 2, 3 and 1 (each within the scatter of the next).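

Up to compound 3, only a methyl or a drawn configuration on the piperazine ring had been varied. Compound 4 shows that in this assay the whole ring, with its defined stereocentre, can be replaced at this position, on an aromatic carbon next to the ring nitrogen, by the open (2-methoxyethyl)amino chain while the number stays within the scatter of all three ring compounds: a 1.1-fold lower number from compound 3 to compound 4 (0.05 log units; within the scatter), a 1.0-fold lower number from compound 2 to compound 4 (0.01 log units; within the scatter) and a 1.2-fold lower number from compound 1 to compound 4 (0.09 log units; within the scatter). Ring or open chain, methyl placement and drawn configuration therefore do not separate these four compounds in this assay, though nothing shown offers a reason for this.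

The compounds shown leave open whether any group at this position would take the number beyond the scatter, for instance a carboxylic acid, a primary amine or a longer chain ending in a morpholine. They also leave open how the numbers in this assay would respond to a change elsewhere on the shared core, such as at the urea or the trifluoromethyl group.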